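The compounds below may be only part of what the source reports. "The series", "measured", "known", "first", "only" and "open" are said of these compounds alone.

Measured in an ADME assay on Akata cells (Homo sapiens) for cytotoxicity, with a stated time of 7 days; a higher number here means that more compound is tolerated, a lower number that less compound is tolerated:

Compound 1 `CCCCCCCCSc1nc(N)nc2c1ncn2/C=C1/CC1(CO)CO`: > 20000 nM
Compound 2 `CSc1nc(N)nc2c1ncn2/C=C1/CC1(CO)CO`: > 20000 nM

Compound 2 stands at > 20000 nM, which is a limit of this assay and not a number. Compound 1 is likewise a limit, at > 20000 nM. All that has been measured so far is therefore (the limit of > 20000 nM in this assay, at which 2 of the 2 values shown sit).

Compound 3 `Nc1nc(SC2CCCC2)c2ncn(/C=C3/CC3(CO)CO)c2n1` is the next compound to be measured. It differs from compound 2 in one place, with cyclopentyl in place of methyl on a sulfur.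

For the measured compounds named here, only one measured step bears on this change, since it also alters the group on that sulfur: a step that the two limits leave unreadable from compound 1 to compound 2, with hydrogen in place of heptyl on a saturated chain carbon bound to a sulfur. That step gives no size to carry over. It shows only that the long chain of compound 1 and the methyl of compound 2 both end at a limit. No step beyond the scatter is therefore expected, and no direction can be given. The estimated step is a step that the limit leaves unreadable from compound 2 to compound 3. In this assay the estimate for compound 3 is 25000 nM, with an expected range of 12000 nM to 50000 nM.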

Compound 3, half-maximal cytotoxic concentration: > 20000 nM
Compound 3: only a limit was reported; the forecaster's own chance of this, stated with the estimate: 85%; the middle value does not contradict the limit.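

In this assay compound 3 gives > 20000 nM, which is a limit of the assay and not a number. No new step can be read among compound 1, compound 2 and compound 3, because all three end at the same limit: the limit of > 20000 nM in this assay, at which 3 of the 3 values shown sit.

The compounds shown leave open whether the group on the sulfur changes the tolerated concentration at all.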